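This account rests on a few compounds, and the source may have more. Where it says the series, first, only, none or still open, it means among the compounds named here.

Measured in a physicochemical assay for solubility, using the shake flask method, in phosphate buffer, measured as kinetic solubility, with a stated time of 20 h, at pH 6.5; a lower number here means a less soluble compound, a higher number a more soluble compound:
- Compound 1 `NC(=O)c1ccc(Nc2cc3[nH]c(-c4cccc(C(F)(F)F)c4)nc3cn2)nc1` gives < 5000 nM (a limit of the assay, not a number)
- Compound 2 `FC(F)(F)c1ccc(Nc2cc3[nH]c(C4CCCC4)nc3cn2)nc1` gives 145000 nM (a number)

Among the compounds with values here, compound 2 therefore holds the only true number on this scale, and the result for compound 1 is only a limit. Compound 3 `FC(F)(F)c1ccc(Nc2cc3[nH]c(CC4CC4)nc3cn2)nc1` carries cyclopropylmethyl in place of cyclopentyl on an aromatic carbon and awaits measurement. Within the data shown here, no measured step guides the expectation in this assay, so only a small upward change, hardly beyond the usual scatter, is expected. The expected step of a 1.2-fold higher number from compound 2 to compound 3 (0.07 log units; within the scatter) is accordingly modest. Compound 3 is estimated at 170000 nM, with an expected range from 70000 nM to 350000 nM.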

Compound 3, solubility: 118000 nM
Compound 3: the middle estimate sits 1.4-fold (0.16 log units) above what was measured, and the stated range covers the measured number.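

In this assay, within the data shown here, this is the first reading of a change at this position, on an aromatic carbon of a five-membered aromatic ring with 2 nitrogen: cyclopropylmethyl in place of cyclopentyl gives a 1.2-fold lower number from compound 2 to compound 3 (0.09 log units; within the scatter) and so stays within the scatter. Exchanging one of these carbon-only ring groups for the other therefore leaves the reading effectively unchanged. Nothing shown bears on the cause of this result. As far as these compounds go, it remains open whether a longer chain, an amine or a carboxylic acid at this position would take the number beyond the scatter.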